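This account rests on a few compounds, and the source may have more. Where it says the series, first, only, none or still open, it means among the compounds named here.

Measured compounds:
- compound 1 `Nc1cccc2c(-c3cccc(NC(=O)c4ccc(Cl)cc4C(F)(F)F)c3)ccnc12`, > 20000 nM
- compound 2 `CC(=O)Nc1cccc2c(-c3cccc(NC(=O)c4ccc(Cl)cc4C(F)(F)F)c3)ccnc12`, > 20000 nM
- compound 3 `Cc1ccc(NC(=O)c2cc(C(F)(F)F)cc(C(F)(F)F)c2)cc1-c1ccnc2c(N)cccc12`, 7400 nM

In a functional assay on A375P cells (Homo sapiens) for antiproliferative activity, read by MTT assay, with a stated time of 48 h (on this read-out lower numbers stand for stronger inhibition and higher numbers for weaker inhibition), compound 1 gives > 20000 nM, a limit of this assay. Compound 2 likewise gives > 20000 nM, again a limit. Within the data shown here, compound 3 gives 7400 nM, the only number in the set. The change from compound 1 to compound 2 is acetyl in place of hydrogen on a nitrogen on an aromatic ring, and its step, a step that the two limits leave unreadable from compound 1 to compound 2, cannot be read because of the limit of > 20000 nM in this assay, at which 2 of the 3 values shown sit. The difference between the core of compound 1 and that of compound 3 is not broken down here.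

Compound 4 `CC(=O)Nc1cccc2c(-c3cc(NC(=O)c4cc(C(F)(F)F)cc(C(F)(F)F)c4)ccc3C)ccnc12` carries the same change on compound 3: acetyl in place of hydrogen on a nitrogen on an aromatic ring. With no readable precedent, a small step is expected, a 1.2-fold higher number from compound 3 to compound 4 (0.09 log units; within the scatter), resting on compound 3 at 7400 nM as the only anchor. Compound 4 is estimated at 9000 nM, between 3000 nM and 20000 nM, with a fair chance that this assay returns only a limit.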

Compound 4, half-maximal inhibitory concentration: > 20000 nM
Compound 4 was reported as a limit; the forecaster's own chance of this, stated with the estimate: 35%; middle value at least 2.2-fold (0.34 log units) away from the limit.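

In this assay acetyl in place of hydrogen on a nitrogen on an aromatic ring gives an at least 2.7-fold higher number from compound 3 to compound 4 (0.43 log units; beyond the scatter) on this core, a weakening beyond the scatter whose full size is not known, since compound 4 returns only a limit. This single readable step sets no rule for the series. The same change on the core of compound 1 cannot be read, so the two cores cannot be compared, because the values sit at the ceiling of the assay: the limit of > 20000 nM in this assay, at which 3 of the 4 values shown sit.

Open, as far as these compounds go, is whether methyl or propanoyl on that nitrogen would keep compound 3 near 7400 nM in this assay. Also open, from the compounds shown here alone, is whether a carboxylic acid in place of the amino group would bring the core of compound 1 into a readable range.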